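This account rests on a few compounds, and the source may have more. Where it says the series, first, only, none or still open, it means among the compounds named here.

Compound 1 `CCOC(=O)c1cnc(-c2ccc(OC)cc2)nc1NN1C(=O)C=C(C)C1=O` gives 900 nM.
Compound 2 `CCOC(=O)c1cnc(-c2ccc(C(F)(F)F)cc2)nc1NN1C(=O)C=C(C)C1=O` gives 400 nM.
Compound 3 `CCOC(=O)c1cnc(-c2ccsc2)nc1NN1C(=O)C=C(C)C1=O` gives 100 nM.

These three compounds share one core and differ only in the aromatic group attached on an aromatic carbon of the six-membered ring with two nitrogens, the position that lies between two ring nitrogen atoms. All were tested in a functional assay on Jurkat cells for inhibition of nuclear factor NF-kappa-B complex (Homo sapiens); a higher number here means a weaker inhibitor, a lower number a stronger inhibitor. Compound 3 gives the lowest number of the three: the change from the 4-methoxyphenyl group gave a 9.0-fold lower number from compound 1 to compound 3 (0.95 log units; beyond the scatter), and the change from the 4-(trifluoromethyl)phenyl group gave a 4.0-fold lower number from compound 2 to compound 3 (0.60 log units; beyond the scatter). The smaller swap on the phenyl ring itself gave a 2.3-fold lower number from compound 1 to compound 2 (0.35 log units; beyond the scatter).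

Compound 4 `CCOC(=O)c1cnc(-c2ccc(C)s2)nc1NN1C(=O)C=C(C)C1=O` keeps the core of compound 3 and alters only the attached group: 5-methylthiophen-2-yl in place of thiophen-3-yl on an aromatic carbon. Going by the values given here, no measured step compares two thiophene groups with each other, so the closest guidance is that swapping the aromatic group on this carbon has so far moved the result in this assay by modest amounts in either direction. The step from compound 3 to compound 4 is therefore expected to be small, a 1.5-fold higher number from compound 3 to compound 4 (0.18 log units; within the scatter), and could fall within the scatter. For compound 4 the estimate in this assay is 150 nM, with a likely range from 50 nM to 450 nM.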

Compound 4, half-maximal inhibitory concentration: 200 nM
Compound 4: middle estimate off by 1.3-fold (0.12 log units), on the low side; measured number inside the range.
By their numbers in this assay, from the lowest: compounds 3, 4 and 2 (each within the scatter of the next, the first and the last beyond it); then compound 1.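

In this assay, the 5-methylthiophen-2-yl group can stand in for thiophen-3-yl without a clear change in the result: the step is a 2.0-fold higher number from compound 3 to compound 4 (0.30 log units; within the scatter), so a thiophene group attached through a different ring carbon and carrying a methyl group can still give a number in the same range. Compared with the phenyl groups, the picture is mixed: the change from the 4-methoxyphenyl group gives a 4.5-fold lower number from compound 1 to compound 4 (0.65 log units; beyond the scatter), whereas the change from the 4-(trifluoromethyl)phenyl group gives a 2.0-fold lower number from compound 2 to compound 4 (0.30 log units; within the scatter), so compound 2 goes against any clean split between thiophene and phenyl groups at this position. Nothing measured here accounts for these numbers.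

Because the attachment point and the methyl group change together from compound 3 to compound 4, the compounds shown cannot separate what each contributes, and a plain thiophen-2-yl group would be the direct link between them. On these data alone, it also remains open how this position would respond to a group outside this aromatic set, such as cyclohexyl, or to a different five-membered aromatic ring, such as furan-3-yl.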